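Swapping Chlorophenyl for Trimethoxyphenyl on the Shared Core

The compounds below may be only part of what the source reports. "The series", "measured", "known", "first", "only" and "open" are said of these compounds alone.

Compound 1 `COc1cc(/C=C/C(=O)c2cccc(-n3cc(-c4ccc(Cl)cc4)[nH]c3=O)c2)cc(OC)c1OC`: 3850 nM
Compound 2 `O=C(/C=C/c1cccc(O)c1)c1cccc(-n2cc(-c3ccc(Cl)cc3)[nH]c2=O)c1`: 990 nM
Compound 3 `COc1ccc(-c2cn(-c3cccc(C(=O)/C=C/c4ccc(O)c(OC)c4)c3)c(=O)[nH]2)cc1`: 4970 nM

All three compounds were tested in a functional assay on OVCAR-8 cells (Homo sapiens) for inhibition; on this read-out lower numbers stand for stronger inhibition of growth and higher numbers for weaker inhibition of growth. Compound 1 gives 3850 nM and stands second highest of the three numbers. Its nearest neighbour is compound 3, whose value lies within the usual scatter of the measurement, so the two cannot be told apart. Compound 2 is the only one clearly set apart: its number is lower than that of compound 1 by a gap beyond the scatter, so compound 2 inhibits growth more strongly.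

Compound 4 `COc1cc(/C=C/C(=O)c2cccc(-n3cc(-c4cc(OC)c(OC)c(OC)c4)[nH]c3=O)c2)cc(OC)c1OC` has not yet been measured. It differs from compound 1 in a single place: 3,4,5-trimethoxyphenyl in place of 4-chlorophenyl on an aromatic carbon. Going by the values given here, nothing among the measured compounds shows what this exchange does, since none of them carries the 3,4,5-trimethoxyphenyl group on the five-membered ring. The expectation can therefore only be modest and wide. A step of no more than the scatter, in either direction, is what is expected, so that from compound 1 to compound 4 the change is estimated as a 1.2-fold lower number from compound 1 to compound 4 (0.08 log units; within the scatter). Compound 4 is thus expected to give about 3200 nM in this assay, with a range from 800 nM to 13000 nM.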

Compound 4, concentration for 50% growth inhibition: 2320 nM
Estimate against measurement, compound 4: 1.4-fold (0.14 log units) above, and the stated range covers the measured number.
By their numbers in this assay, from the lowest: compound 2; then compounds 4, 1 and 3 (each within the scatter of the next, the first and the last beyond it).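

Going by these compounds alone, this step gives the first direct look at the aromatic carbon of the five-membered ring in this assay: placing 3,4,5-trimethoxyphenyl there instead of 4-chlorophenyl gives a 1.7-fold lower number from compound 1 to compound 4 (0.22 log units; within the scatter), and the two compounds cannot be told apart. The entering group has 12 heavy atoms against 7 and 3 hydrogen-bond acceptors against 0, so this one exchange shows that a clearly larger aryl group at this carbon can stand in for 4-chlorophenyl without a change in growth inhibition beyond the scatter. Nothing measured here gives a reason for this result.

Still open, going by these compounds, is whether a plain phenyl, a pyridine ring or a phenyl carrying a carboxylic acid or an amine on this same carbon would also read the same, since a single step cannot describe the whole position. Also open, on these data alone, is whether the exchange would behave alike with the other end of the molecule taken from compound 2, which gives 990 nM with the 4-chlorophenyl group in place.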